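Side chain on the carbonyl carbon: compound 2 to compound 3

The source may report more compounds than this note shows. Statements on the series, on what has been measured and on what is new or still open speak of the compounds shown alone.

Of the compounds shown here, two have numbers so far in a functional assay on A549 cells (Homo sapiens) for inhibition, read by MTT assay, with a stated time of 72 h; on this read-out higher numbers stand for weaker inhibition and lower numbers for stronger inhibition. Compound 1 (`COc1cc(N(C)CCN(C)C)c(NC(=O)C=C(C)C)cc1Nc1nc2c(c(-c3cn(C)c4ccc(F)cc34)n1)CSCC2`) gives 902 nM, and compound 2 (`COc1cc(N(C)CCN(C)C)c(NC(=O)C=C(C)C)cc1Nc1nc2c(c(-c3cn(C)c4ccccc34)n1)CSCC2`) gives 583 nM. Compound 2 therefore stands level with compound 1 within the scatter, and neither number separates from the other.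

Compound 3 (`CCC/C=C\C(=O)Nc1cc(Nc2nc3c(c(-c4cn(C)c5ccccc45)n2)CSCC3)c(OC)cc1N(C)CCN(C)C`) keeps the shared core of compound 2 and changes one group: pent-1-en-1-yl in place of 2-methylprop-1-en-1-yl on a carbonyl carbon. In words, this is pent-1-en-1-yl in place of 2-methylprop-1-en-1-yl on a carbonyl carbon.

Among the compounds with values here, only one measured step exists, a 1.5-fold lower number from compound 1 to compound 2 (0.19 log units; within the scatter). It is hydrogen in place of fluoro on an aromatic carbon, so it says nothing directly about a change on the carbonyl carbon. Within the data shown here, no measured compound yet varies this group, and no direction can be drawn from the numbers in hand. The working expectation in this assay is therefore no shift beyond the scatter, with a wide margin on either side.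

The expected change is a 1.0-fold higher number from compound 2 to compound 3 (0.01 log units; within the scatter).

Compound 3 is estimated at 600 nM, with an expected range of 220 nM to 1600 nM.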

Compound 3, half-maximal inhibitory concentration: 571 nM
Compound 3: middle estimate off by 1.1-fold (0.02 log units), on the high side, and the stated range covers the measured number.
By their numbers in this assay, from the lowest: compounds 3, 2 and 1 (each within the scatter of the next).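

In this assay, within the data shown here, the first variation of the group on the carbonyl carbon gives a 1.0-fold lower number from compound 2 to compound 3 (0.01 log units; within the scatter) and so does not separate pent-1-en-1-yl from 2-methylprop-1-en-1-yl at this place. The two groups differ by one carbon, 5 heavy atoms against 4, while both have no ring, 1 double bond outside aromatic rings, no hydrogen-bond donors or acceptors and no net charge, so this step samples only a narrow change in the carbon chain on the amide carbonyl. No supporting data are available to explain why these two groups give matching readings.

The compounds shown leave open whether a plain ethenyl group, a longer chain such as hept-1-en-1-yl, or an alkene chain carrying a dimethylamino group would also read level with these two at the carbonyl carbon. As far as these compounds go, it also remains open whether pent-1-en-1-yl would read the same when combined with the fluoro group of compound 1.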